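From Aryl to Hydrogen on an Amine Nitrogen

This account rests on a few compounds, and the source may have more. Where it says the series, first, only, none or still open, it means among the compounds named here.

Compound 1 `Cc1ccc(S(=O)(=O)/N=C(/CCNC2=CC(=O)c3ccccc3C2=O)Nc2cccc(C(F)(F)F)c2)cc1` was tested in a functional assay on MCF7 cells (Homo sapiens) for cytotoxicity, read by MTT assay, with a stated time of 48 h (a higher number here means a weaker inhibitor, a lower number a stronger inhibitor), where compound 1 gives 89100 nM. That is the highest of the three numbers measured here, and both other compounds stand beyond the scatter below it. Compound 2 `Cc1ccc(S(=O)(=O)/N=C(/CCNC2=CC(=O)c3ccccc3C2=O)NC2CCCCC2)cc1` gives 7580 nM in this assay, and compound 3 `COc1ccc(N/C(CCNC2=C(Br)C(=O)c3ccccc3C2=O)=N\S(=O)(=O)c2ccc(C)cc2)cc1OC` gives 6610 nM. Compound 4 `Cc1ccc(S(=O)(=O)/N=C(\N)CCNC2=CC(=O)c3ccccc3C2=O)cc1` has not yet been measured; it differs from compound 1 by hydrogen in place of 3-(trifluoromethyl)phenyl on an amine nitrogen. Going by the values given here, one measured step bears on this change: a 12-fold lower number from compound 1 to compound 2 (1.07 log units; beyond the scatter), where the same 3-(trifluoromethyl)phenyl group left and cyclohexyl entered. Compound 4 goes further, leaving only hydrogen on that amine nitrogen. Among the compounds with values here, since that one comparable step was large and pointed downward, a lower number is expected for compound 4 as well, though the uncertainty is wide because a 12-fold lower number from compound 1 to compound 2 (1.07 log units; beyond the scatter) is the only step available. Compound 4 is therefore expected at 15000 nM, between 3000 nM and 70000 nM, which means an expected 5.9-fold lower number from compound 1 to compound 4 (0.77 log units; beyond the scatter).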

Compound 4, half-maximal inhibitory concentration: 18600 nM
Beside the measured number, compound 4's estimate is 1.2-fold (0.09 log units) below it, within the range that was stated.
By their numbers in this assay, from the lowest: compounds 3 and 2 (each within the scatter of the next); then compound 4; then compound 1.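

Taking the aromatic group off altogether still gives a 4.8-fold lower number from compound 1 to compound 4 (0.68 log units; beyond the scatter) in this assay, so with hydrogen alone on this amine nitrogen the number is already lower than with 3-(trifluoromethyl)phenyl. Cyclohexyl goes further, as hydrogen in its place gives a 2.5-fold higher number from compound 2 to compound 4 (0.39 log units; beyond the scatter), so compared with hydrogen, one group on this nitrogen raises the number and the other lowers it. No measurement here explains this order.

As far as these compounds go, whether the lower number belongs to cyclohexyl alone, or also appears with a methyl group, a longer chain or a plain phenyl ring on this nitrogen, remains open. Also open, from the compounds shown here alone, is whether the same order holds on the bromine-bearing core of compound 3.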